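Adding one carbon to a weakly cytotoxic compound

A few compounds are considered here, and "the series" means these few. Any claim that something is new, unique, unknown or untested is made for them only; others in the source may bear on it.

Compound 1 `Cc1cc(-c2c(-c3cccc(C)n3)nn3c2C(C)C(C)(C)C3)ccn1` gives > 100000 nM (a limit, not a number)
Compound 2 `Cc1cccc(-c2nn3c(c2-c2ccnc(Nc4ccc(S(N)(=O)=O)cc4)c2)C(C)C(C)(C)C3)n1` gives 22000 nM
Compound 3 `Cc1cccc(-c2nn3c(c2-c2ccncc2)C(C)C(C)(C)C3)n1` gives > 100000 nM (a limit, not a number)

Compound 2 at 22000 nM holds the only true number in a functional assay on MCF7 cells (Homo sapiens) for cytotoxicity, with a stated time of 72 h (on this read-out higher numbers stand for weaker inhibition and lower numbers for stronger inhibition), among these three. Compound 1 and compound 3 both rest at the limit of > 100000 nM in this assay, at which 2 of the 3 values shown sit, and neither gives a number.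

Compound 4 `CCc1cccc(-c2nn3c(c2-c2ccnc(Nc4ccc(S(N)(=O)=O)cc4)c2)C(C)C(C)(C)C3)n1` has not been measured. It turns 6-methylpyridin-2-yl into 6-ethylpyridin-2-yl (methyl in place of hydrogen on a saturated chain carbon bound to an aromatic carbon) with methyl in place of hydrogen on a saturated chain carbon bound to an aromatic carbon.

Two measured steps are clear: an at least 4.5-fold lower number from compound 1 to compound 2 (0.65 log units; beyond the scatter) and an at least 4.5-fold higher number from compound 2 to compound 3 (0.65 log units; beyond the scatter). Both change the (4-sulfamoylphenyl)amino group, which compound 4 keeps, so neither measures this change directly. The closest in kind is a step that the two limits leave unreadable from compound 1 to compound 3 and it gives no size. In this assay the expected step is therefore a 1.1-fold lower number from compound 2 to compound 4 (0.04 log units; within the scatter) with no move beyond the usual scatter foreseen. Compound 4 is expected at 20000 nM within an estimated range from 8000 nM to 60000 nM.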

Compound 4, half-maximal inhibitory concentration: 28000 nM
Compound 4: the middle estimate sits 1.4-fold (0.15 log units) below what was measured, within the range that was stated.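

In this assay, turning 6-methylpyridin-2-yl into 6-ethylpyridin-2-yl gives a 1.3-fold higher number from compound 2 to compound 4 (0.10 log units; within the scatter), so compound 2 and compound 4 cannot be told apart. For the compounds shown here, the earlier readable steps all changed the (4-sulfamoylphenyl)amino group, so this is the first reading of a change at the 6-methylpyridin-2-yl group itself: with the (4-sulfamoylphenyl)amino group in place, one added carbon leaves the cytotoxicity where it was. Nothing measured here gives a reason for this result.

This single step does not show whether a longer chain such as propyl, or an amine at the same place, would read the same way. It also leaves open whether the ethyl group would behave alike without the (4-sulfamoylphenyl)amino group, as in compound 3, whose > 100000 nM is a limit and not a number.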